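A few compounds are considered here, and "the series" means these few. Any claim that something is new, unique, unknown or untested is made for them only; others in the source may bear on it.

Measured in an ADME assay on microsomes from liver (Homo sapiens) for metabolic stability, with a stated time of 10 min (on this read-out lower numbers stand for a less stable compound and higher numbers for a more stable compound), so far:
- compound 1 `C[C@]1(C(=O)N2CC[C@](c3ccc(C(F)(C(F)(F)F)C(F)(F)F)cc3)(S(=O)(=O)c3ccc(F)cc3)C2)CC[C@H](C(=O)O)CC1` gives 80%
- compound 2 `O=C(O)[C@H]1CC[C@](F)(C(=O)N2CC[C@](c3ccc(C(F)(C(F)(F)F)C(F)(F)F)cc3)(S(=O)(=O)c3ccc(F)cc3)C2)CC1` gives "not determined" (no result reported)
- compound 3 `O=C(O)C12CCC(C(=O)N3CC[C@](c4ccc(C(F)(C(F)(F)F)C(F)(F)F)cc4)(S(=O)(=O)c4ccc(F)cc4)C3)(CC1)OC2` gives 90%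

Compound 3 at 90% lies within the usual scatter of compound 1 and cannot be separated from it, while compound 2 offers no number for comparison. The change from compound 3 to compound 4 `O=C([C@H]1CC[C@H](c2nnn[nH]2)CC1)N1CC[C@](c2ccc(C(F)(C(F)(F)F)C(F)(F)F)cc2)(S(=O)(=O)c2ccc(F)cc2)C1` is a group of 11 heavy atoms (7 carbon, 4 nitrogen; one five-membered aromatic ring with 4 hetero atoms, one six-membered non-aromatic ring of carbon only) in place of a group of 11 heavy atoms (8 carbon, 3 oxygen; one six-membered non-aromatic ring of carbon only, one six-membered non-aromatic ring with 1 hetero atom), on a carbonyl carbon and it puts a 4-(1H-tetrazol-5-yl)cyclohexyl group on a carbonyl carbon whose other neighbours are: amide-type nitrogen in a ring. Going by the values given here, the one measured step of a number 10 percentage points higher from compound 1 to compound 3 (within the scatter) also exchanges the group at that place and is the only guide available. Among the compounds with values here, it is a weak guide, as no measured compound carries the five-membered aromatic ring with 4 hetero atoms. On the strength of the step of a number 10 percentage points higher from compound 1 to compound 3 (within the scatter) no change beyond the scatter is expected in this assay for this exchange. The expected change is a number 8 percentage points lower from compound 3 to compound 4 (within the scatter) and it stays within the scatter. Compound 4 is estimated at 82% with 65% to 95% as the expected range.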

Compound 4, percent of the compound remaining: 100%
The estimate for compound 4 lay 18 percentage points below the measured number; the whole stated range lies below it.
By their numbers in this assay, from the lowest: compounds 1, 3 and 4 (each within the scatter of the next, the first and the last beyond it).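

In this assay, going by these compounds alone, the 4-(1H-tetrazol-5-yl)cyclohexyl group on the carbonyl carbon gives the first step at this place that goes beyond the scatter, a number 20 percentage points higher from compound 1 to compound 4 (beyond the scatter), and it does so with a tetrazole ring where the earlier compounds carry a carboxylic acid. The other step, a number 10 percentage points higher from compound 3 to compound 4 (within the scatter), does not separate the two groups it exchanges. Nothing measured here accounts for either step.

As far as these compounds go, the step to 4-(1H-tetrazol-5-yl)cyclohexyl exchanges the carboxylic acid and removes the methyl of 4-carboxy-1-methylcyclohexyl together, so the share of each stays open. Also open, from the compounds shown here alone, is how this read-out would respond to a primary amide or a methyl ester on the cyclohexyl ring at this place.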